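Replacing a carboxypiperidine with hydroxy on the benzylic carbon

The compounds below may be only part of what the source reports. "The series", "measured", "known", "first", "only" and "open" are said of these compounds alone.

Three analogues of one cis-stilbene core have been tested in a functional assay on HeLa cells (Homo sapiens) for antiproliferative activity, read by CCK-8 assay, with a stated time of 48 h; a higher number here means a weaker inhibitor, a lower number a stronger inhibitor. Compound 1 `COc1ccc(/C=C\c2cc(OC)c(OC)c(OC)c2)cc1OCc1ccc(CN2CCCC[C@H]2C(=O)O)cc1` returns only a limit in this assay, > 10000 nM. Compound 2 `COc1ccc(/C=C\c2cc(OC)c(OC)c(OC)c2)cc1OCc1ccc(CN2CC[C@@H](C(=O)O)C2)cc1` gives 12800 nM in this assay. Compound 3 `COc1ccc(/C=C\c2cc(OC)c(OC)c(OC)c2)cc1OCc1ccc(CN[C@H](C(=O)O)[C@@H](C)O)cc1` also returns only a limit, > 10000 nM. Going by the values given here, compound 1 therefore stands at the limit together with compound 3, as the limit of > 10000 nM in this assay, at which 2 of the 3 values shown sit, records, and no measured step from it can be sized: the step that the limit leaves unreadable from compound 1 to compound 2 is unreadable, as is a step that the two limits leave unreadable from compound 1 to compound 3, and likewise a step that the limit leaves unreadable from compound 2 to compound 3.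

The unmeasured compound 4 `COc1ccc(/C=C\c2cc(OC)c(OC)c(OC)c2)cc1OCc1ccc(CO)cc1` differs from compound 1 as follows: hydroxy in place of 2-carboxypiperidin-1-yl on a saturated chain carbon bound to an aromatic carbon. All three measured compounds carry an amino acid on that saturated chain carbon bound to an aromatic carbon, and every one of them is weak or at the limit, so the measured steps say nothing about what removing the acid altogether does; they only show that exchanging one acid for another did not lift any compound clearly into a readable range. The change to a hydroxymethyl group is of a different kind and its size is not predicted by the data.

Compound 4 is therefore estimated at 6000 nM, within 1000 nM to 30000 nM, which corresponds to an expected step of an at least 1.6-fold lower number from compound 1 to compound 4 (0.22 log units; that floor lies within the scatter).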

Compound 4, half-maximal inhibitory concentration: 7600 nM
The estimate for compound 4 lay 1.3-fold (0.10 log units) below the measured number; the range from low to high includes it.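

In this assay, the change to hydroxy is the first shown at this position that removes the carboxylic acid altogether, and the one fully sized comparison reads a 1.7-fold lower number from compound 2 to compound 4 (0.23 log units; within the scatter), so hydroxy and 3-carboxypyrrolidin-1-yl on this saturated chain carbon cannot be told apart here. As far as these compounds go, the comparisons with the other two compounds give only floors, an at least 1.3-fold lower number from compound 1 to compound 4 (0.11 log units; that floor lies within the scatter) and an at least 1.3-fold lower number from compound 3 to compound 4 (0.11 log units; that floor lies within the scatter), so the true size of these steps stays open, and the steps among the three acid-bearing compounds cannot be read at all. Compound 1 and compound 3 therefore remain limits rather than numbers: the limit of > 10000 nM in this assay, at which 2 of the 4 values shown sit.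

The compounds shown leave open whether a plain piperidin-1-yl group without the carboxylic acid, a simple amine or a methyl ether on this carbon would give a number different from that of compound 4, and whether a longer chain carrying the hydroxy group would do so. They also leave open whether any group at this position can bring the number clearly beyond the scatter of compound 4 in this assay.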